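This account rests on a few compounds, and the source may have more. Where it says the series, first, only, none or still open, it means among the compounds named here.

Measured compounds:
Compound 1, `CC(C)(Oc1ccccc1)C1OCC(C/C=C\CCC(=O)O)C(c2cccnc2)O1`: in an assay for inhibition of prostacyclin synthase (Homo sapiens), using microsomes (on this read-out lower numbers stand for stronger inhibition and higher numbers for weaker inhibition), compound 1 gives 75000 nM.
Compound 2, `Cc1ccc(C#N)c(OC(C)(C)C2OCC(C/C=C\CCC(=O)O)C(c3cccnc3)O2)c1`: for compound 2 this assay reports only a limit, > 100000 nM.
Compound 3, `COc1ccccc1OC(C)(C)C1OCC(C/C=C\CCC(=O)O)C(c2cccnc2)O1`: compound 3 gives 51000 nM.

Compound 3 carries the lowest of the two numbers shown, but the gap to its nearest neighbour, a 1.5-fold lower number from compound 1 to compound 3 (0.17 log units; within the scatter), is within the scatter of the method, so the two are not separated. Compound 2 sits at the limit of the assay, (the limit of > 100000 nM in this assay, at which 1 of the 3 values shown sits), and the step of an at least 1.9-fold lower number from compound 2 to compound 3 (0.29 log units; that floor lies within the scatter) is a floor that also lies within the scatter. The whole set therefore shows only weak inhibition with no step beyond the scatter.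

The next compound is compound 4, `CC(C)(Oc1ccccc1Br)C1OCC(C/C=C\CCC(=O)O)C(c2cccnc2)O1`. Its change from compound 3 reads: bromo in place of methoxy on an aromatic carbon. Among the compounds with values here, no measured pair swaps bromo for methoxy; the only step at that ring position, a 1.5-fold lower number from compound 1 to compound 3 (0.17 log units; within the scatter), adds methoxy to hydrogen and is within the scatter, and the aryl swap an at least 1.9-fold lower number from compound 2 to compound 3 (0.29 log units; that floor lies within the scatter) is likewise not resolved.

On that basis no step beyond the scatter is expected in this assay, a 1.2-fold higher number from compound 3 to compound 4 (0.07 log units; within the scatter), with a real chance that the value lands at the limit. Compound 4 is estimated at 60000 nM, within a range from 25000 nM to 150000 nM.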

Compound 4, half-maximal inhibitory concentration: 7000 nM
Compound 4: middle estimate off by 8.6-fold (0.93 log units), on the high side; measured number below the stated range.
By their numbers in this assay, from the lowest: compound 4; then compounds 3 and 1 (each within the scatter of the next). At a limit, above all of these: compound 2.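

The aromatic carbon ortho to a large group proves responsive in this assay: bromo gives steps beyond the scatter against both methoxy, a 7.3-fold lower number from compound 3 to compound 4 (0.86 log units; beyond the scatter), and hydrogen, an 11-fold lower number from compound 1 to compound 4 (1.03 log units; beyond the scatter), whereas methoxy in place of hydrogen at this carbon stays within the scatter, a 1.5-fold lower number from compound 1 to compound 3 (0.17 log units; within the scatter). So the outcome at this carbon depends on which group enters, and the 2-bromophenyl group also separates from the 2-cyano-5-methylphenyl group, an at least 14-fold lower number from compound 2 to compound 4 (1.15 log units; beyond the scatter), though that step is only a floor. Compound 2 gives a limit, not a number: the limit of > 100000 nM in this assay, at which 1 of the 4 values shown sits.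

The compounds shown leave open whether chloro, iodo or trifluoromethyl at this carbon would match bromo, and so whether the step is particular to bromo or shared by other groups. They also do not tell what separates bromo from methoxy and hydrogen, or whether bromo on a different carbon of the ring would give a step of similar size.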